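A few compounds are considered here, and "the series" means these few. Any claim that something is new, unique, unknown or untested is made for them only; others in the source may bear on it.

Compound 1, `O[C@H]1Cc2ccccc2C1NC1CCN(CCCc2c[nH]c3ccc(-n4cnnc4)cc23)CC1`, in an assay on CHO cells for displacement of a labelled ligand from 5-hydroxytryptamine receptor 1D (Homo sapiens) (on this read-out lower numbers stand for stronger inhibition and higher numbers for weaker inhibition), gives 37 nM.
Compound 2, `c1ccc(CNCC2CCN(CCCc3c[nH]c4ccc(-n5cnnc5)cc34)CC2)cc1`, in this assay gives 1.6 nM.
Compound 3, `CN(C1CCN(CCCc2c[nH]c3ccc(-n4cnnc4)cc23)CC1)S(=O)(=O)c1ccccc1`, in this assay gives 1.5 nM.

All three share one core and differ only in the group attached to a saturated ring carbon. Compound 2 stands second highest of the three numbers. Its nearest neighbour is compound 3, with a 1.1-fold lower number from compound 2 to compound 3 (0.03 log units; within the scatter), a gap within the scatter. Its furthest neighbour is compound 1, from which the step is a 23-fold lower number from compound 1 to compound 2 (1.36 log units; beyond the scatter), and the parallel step is a 25-fold lower number from compound 1 to compound 3 (1.39 log units; beyond the scatter).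

Compound 4, `CC(=O)Nc1ccc(CNCC2CCN(CCCc3c[nH]c4ccc(-n5cnnc5)cc34)CC2)cc1`, keeps the whole of compound 2 and adds one group on its outer aromatic ring: acetamido in place of hydrogen on an aromatic carbon.

Among the compounds with values here, none of the measured steps touches that aromatic ring; each of them swaps the entire group on the saturated ring carbon. The two large steps, a 23-fold lower number from compound 1 to compound 2 (1.36 log units; beyond the scatter) and a 25-fold lower number from compound 1 to compound 3 (1.39 log units; beyond the scatter), show that this region matters, while a 1.1-fold lower number from compound 2 to compound 3 (0.03 log units; within the scatter) shows that two rather different groups carrying a phenyl ring land at the same number. The change from compound 2 to compound 4 is a smaller one, further from the core, so no step beyond the scatter is expected in this assay.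

Compound 4 is therefore estimated at 2 nM, with a range from 0.6 nM to 6.5 nM. That estimate means an expected step of a 1.3-fold higher number from compound 2 to compound 4 (0.10 log units; within the scatter).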

Compound 4, half-maximal inhibitory concentration: 4.2 nM
Compound 4: the middle estimate sits 2.1-fold (0.32 log units) below what was measured; the measured number falls inside the stated range.
By their numbers in this assay, from the lowest: compounds 3 and 2 (each within the scatter of the next); then compound 4; then compound 1.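

Until now every step swapped the whole group on the saturated ring carbon, so nothing showed what a change on the outer aromatic ring itself would do. In this assay, acetamido in place of hydrogen on that ring, para to a large group, gives a 2.6-fold higher number from compound 2 to compound 4 (0.42 log units; beyond the scatter) and so weakens inhibition modestly but beyond the scatter, a far smaller shift than the swap of the whole group seen in a 23-fold lower number from compound 1 to compound 2 (1.36 log units; beyond the scatter) and showing that this outer ring accepts the added acetamido at a limited cost. Nothing measured here explains why the number rises, so the cause of this step stays unknown.

With only one group at one place, the compounds shown cannot tell whether the rise belongs to acetamido in particular or would come with any group on that carbon. Open too, on these data alone, is whether fluoro, methoxy, an amine or a carboxylic acid at the same place would stay within the scatter of compound 2, and whether acetamido on another carbon of the ring would give the same number.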